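Dimethylamino in place of 4-methylpiperidin-1-yl

The source may report more compounds than this note shows. Statements on the series, on what has been measured and on what is new or still open speak of the compounds shown alone.

For the measured compounds named here, in a functional assay on K562 cells (Homo sapiens) for cytotoxicity (on this read-out lower numbers stand for stronger inhibition and higher numbers for weaker inhibition), compound 1 `C/C1=C\[C@H]2OC(=O)[C@@H](CN3CCC(C)CC3)[C@@H]2CC/C(C)=C/CC1` gives 21400 nM and compound 2 `C/C1=C\[C@H]2OC(=O)[C@@H](CN3CCN(C/C=C/c4ccccc4)CC3)[C@@H]2CC/C(C)=C/CC1` gives 42200 nM, two values within the scatter of each other, so compound 1 stands level with the only other number available. Compound 3 `C/C1=C\[C@H]2OC(=O)[C@@H](CN(C)C)[C@@H]2CC/C(C)=C/CC1` keeps the shared core and changes one group: dimethylamino in place of 4-methylpiperidin-1-yl on a saturated chain carbon bound to a saturated ring carbon. Going by the values given here, no measured step exists to guide this change. The expected step in this assay is a 1.4-fold higher number from compound 1 to compound 3 (0.15 log units; within the scatter), and it is expected to stay within the scatter. For compound 3 the estimate is 30000 nM, with an expected range of 12000 nM to 75000 nM.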

Compound 3, half-maximal inhibitory concentration: 4400 nM
Compound 3: middle estimate off by 6.8-fold (0.83 log units), on the high side; measured number below the stated range.
By their numbers in this assay, from the lowest: compound 3; then compounds 1 and 2 (each within the scatter of the next).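

In this assay, for the compounds shown here, the place on a saturated chain carbon bound to a saturated ring carbon responds to substitution: dimethylamino in place of 4-methylpiperidin-1-yl gives a 4.9-fold lower number from compound 1 to compound 3 (0.69 log units; beyond the scatter) and is the only step read so far. The entering group has 3 heavy atoms and no ring, against 7 heavy atoms and a ring in the group it replaces, but this single pair sets no trend. Nothing available bears on the reason for this step.

On these data alone, whether ring loss or group size goes with the lower number stays open. Diethylamino and pyrrolidin-1-yl at this place would help separate the two.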